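This account rests on a few compounds, and the source may have more. Where it says the series, first, only, none or still open, it means among the compounds named here.

Compound 1, `COc1cc2ncnc(Nc3ccc(B(O)O)cc3)c2cc1OC`: 49%
Compound 2, `COCCOc1cc2ncnc(Nc3cccc(B(O)O)c3)c2cc1OC`: 19%

In an assay on isolated protein for inhibition of vascular endothelial growth factor receptor 1 (Homo sapiens), read by ELISA, with a stated time of 20 min, tested at 1 uM (on this read-out lower numbers stand for less inhibition and higher numbers for more inhibition at the one concentration tested (going by the name of the read-out)), compound 2 gives the lower of the two numbers seen so far; compound 1 stands well above it, by more than the scatter, though the two differ in two places at once, so the numbers alone do not say which change matters. Compound 3, `COCCOc1cc2ncnc(Nc3ccc(B(O)O)cc3)c2cc1OC`, has not yet been measured. It differs from compound 2 in one way: a group of 9 heavy atoms (6 carbon, 1 boron, 2 oxygen; one six-membered aromatic ring of carbon only) in place of a group of 9 heavy atoms (6 carbon, 1 boron, 2 oxygen; one six-membered aromatic ring of carbon only), on a nitrogen on an aromatic ring. With no single-change comparison available, the expected step from compound 2 to compound 3 in this assay is a moderate rise, a number 21 percentage points higher from compound 2 to compound 3 (beyond the scatter), mostly because compound 1 gives 49% with the same arrangement of the boronic acid. Compound 3 is thus estimated at 40%, within 20% to 60%.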

Compound 3, a percentage reported as inhibition, at one concentration (the size of the read-out at that concentration, not a potency): "not active" (no number reported)
Nothing numeric was reported for compound 3, so the estimate cannot be set against anything.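

In this assay, among these compounds, compound 3 gives "not active" (no number reported), without a number, so no step from compound 2 to compound 3 can be read. Which of the two differences between compound 1 and compound 2 matters stays open. No other measurement here bears on this result.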